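Cytotoxicity notes on an amide series, compound 2 to 3

The compounds below may be only part of what the source reports. "The series", "measured", "known", "first", "only" and "open" are said of these compounds alone.

Measured so far:
compound 1 `COc1ccc(-n2c(SC(C)C(=O)Nc3ccc(Cl)cn3)nc3ccccc32)cc1`: "not determined" (no result reported) in an ADME assay on Vero cells (Chlorocebus sabaeus) for cytotoxicity, read by MTT assay, with a stated time of 24 h; a lower number here means that less compound is tolerated, a higher number that more compound is tolerated
compound 2 `COc1ccc(-n2c(SC(C)C(=O)Nc3ncc(C)cc3Cl)nc3ccccc32)cc1`: 880 nM

Among the compounds with values here, compound 2 is the only member of the series with a number in this assay; for compound 1 the entry reads "not determined" (no result reported), so nothing can be said of how the two compare. Compound 2 therefore stands alone, and its value of 880 nM is the only anchor for anything further.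

Compound 3 `COc1ccc(-n2c(SC(C)C(=O)Nc3cc(C)nn3C)nc3ccccc32)cc1` differs from compound 2 in one place: 1,3-dimethyl-1H-pyrazol-5-yl in place of 3-chloro-5-methylpyridin-2-yl on an amide-type nitrogen. Within the data shown here, no step between measured compounds is available to calibrate what such a change does in this assay, so any expectation rests on compound 2 alone.

For the step from compound 2 to compound 3 a small change is expected, a 1.7-fold higher number from compound 2 to compound 3 (0.23 log units; within the scatter), toward a slightly higher number, though this may well fall within the scatter. Compound 3 is thus estimated at 1500 nM in this assay, with a range from 500 nM to 5000 nM.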

Compound 3, half-maximal cytotoxic concentration: 75000 nM
Beside the measured number, compound 3's estimate is 50-fold (1.70 log units) below it; measured number outside the range, above it.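

In this assay, within the data shown here, the place on the amide-type nitrogen turns out to be one that counts: 1,3-dimethyl-1H-pyrazol-5-yl in place of 3-chloro-5-methylpyridin-2-yl gives an 85-fold higher number from compound 2 to compound 3 (1.93 log units; beyond the scatter), the first step that can be read at all, and it points toward more compound being tolerated. The change is not a single feature, since a six-membered aromatic ring gives way to a five-membered aromatic ring, the chlorine leaves and the number of ring hetero atoms changes, so this one step cannot assign the shift to any one of these. Nothing measured here bears on why the number rises so far.

Still open, as far as these compounds go, is whether the higher number follows the loss of the chlorine or the change of ring, which a 5-methylpyridin-2-yl group carrying no chlorine would begin to separate from the pyrazole. Also open, from the compounds shown here alone, is how far the trend extends to other groups on this nitrogen, such as a plain phenyl or a pyrazole bearing a carboxylic acid, since a single step defines no trend.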